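Removing a benzyl from an inactive compound

The source may hold more compounds than are shown below. What is called first, only, known or untested is meant among the compounds shown, and "the series" means these compounds.

In a functional assay on the whole organism for inhibition, with Felis catus as the target, with a stated time of 30 min (a higher number here means that more compound is needed for the effect, a lower number that less compound is needed), compound 1 `OC(CNCCOc1ccccc1)COc1ccccc1` gives 0.054 mg/kg. Compound 2 `OC(CNCCOc1ccccc1)COc1ccc(OCc2ccccc2)cc1` is reported as "not active" (no number reported), so it has no number to compare. Compound 3 `Oc1ccc(OCC(O)CNCCOc2ccccc2)cc1` differs from compound 2 in one place: hydrogen in place of benzyl on an oxygen on an aromatic ring. Going by the values given here, no measured step of this kind is available as a guide. A large step beyond the scatter is expected, from no activity to a measurable dose, landing in the region of compound 1 at 0.054 mg/kg. For compound 3 the estimated dose is 0.1 mg/kg, with an expected range of 0.02 mg/kg to 0.6 mg/kg.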

Compound 3, dose for half-maximal effect: 0.031 mg/kg
Compound 3: the middle estimate sits 3.2-fold (0.51 log units) above what was measured; low and high end bracket the measured number.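

The hydroxy on the aromatic carbon is accepted at this position: in this assay the data show (a 1.7-fold lower number from compound 1 to compound 3 (0.24 log units; within the scatter)), so compound 1 and compound 3 cannot be told apart. Compound 2 alone is reported as not active, which ties the loss to the benzyl on the oxygen rather than to the oxygen itself. No measurement here explains why the benzyl has this effect. Going by these compounds, whether a methoxy, a small ether, would behave like the hydroxy or like the benzyloxy stays open. So does the outcome with an amine at this position.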